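A few compounds are considered here, and "the series" means these few. Any claim that something is new, unique, unknown or untested is made for them only; others in the source may bear on it.

In a functional assay on NCI-H23 cells (Homo sapiens) for cytotoxicity, read by sulforhodamine B assay, with a stated time of 72 h (a lower number here means a stronger inhibitor of growth, a higher number a weaker inhibitor of growth), compound 1 `CCCC(=O)N1c2ccccc2CCC1C(=O)Nc1ccccc1C(F)(F)F` gives > 70000 nM, which is a limit of the assay and not a number. Among the compounds with values here, compound 2 `O=C(Nc1ccccc1C(F)(F)F)C1CCc2ccccc2N1C(=O)c1ccc(Cl)cc1` gives 307 nM, the only true number so far. Within the data shown here, the one measured step, an at least 220-fold lower number from compound 1 to compound 2 (2.35 log units; beyond the scatter), is large and beyond the scatter, and it comes with 4-chlorophenyl in place of propyl on a carbonyl carbon. Its size rests on (the limit of > 70000 nM in this assay, at which 1 of the 2 values shown sits).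

Compound 3 `O=C(Nc1ccccc1C(F)(F)F)C1CCc2ccccc2N1C(=O)c1ccccc1Cl` keeps the shared core and has 2-chlorophenyl in place of 4-chlorophenyl on a carbonyl carbon. Among the measured compounds shown here, no measured pair compares these two groups directly, so the evidence is indirect. Compound 3 still carries a chlorophenyl group at that carbonyl carbon, the kind of group that came with an at least 220-fold lower number from compound 1 to compound 2 (2.35 log units; beyond the scatter), so a far smaller step is expected here, with a higher number in this assay somewhat more likely than a lower one. The estimated change is a 2.6-fold higher number from compound 2 to compound 3 (0.42 log units; beyond the scatter). For compound 3 the expected value is 800 nM, with an estimated range of 150 nM to 5000 nM.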

Compound 3, concentration for 50% growth inhibition: 2150 nM
Compound 3: middle estimate off by 2.7-fold (0.43 log units), on the low side; low and high end bracket the measured number.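

In this assay, 2-chlorophenyl in place of 4-chlorophenyl on a carbonyl carbon gives a 7.0-fold higher number from compound 2 to compound 3 (0.85 log units; beyond the scatter), so these two groups, with the same atoms and the same counts, are not interchangeable at this position: having a chlorophenyl group there does not by itself set the number, and where the chlorine sits on the ring also matters. The step from the propyl group remains large, an at least 32-fold lower number from compound 1 to compound 3 (1.51 log units; beyond the scatter), so both chlorophenyl groups shown go with a lower number than propyl, and the 2-chlorophenyl group keeps a substantial part of that difference. The size of this step is only a bound, since compound 1 stands at a limit of the assay and not at a number: the limit of > 70000 nM in this assay, at which 1 of the 3 values shown sits.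

The compounds shown leave open whether a plain phenyl group or a fluorophenyl group at this carbonyl carbon would fall with the chlorophenyl groups, so the share of the aromatic ring and the share of the chlorine cannot yet be separated. They also leave open whether the order of the two chlorophenyl groups would hold with a plain phenyl group in place of the trifluoromethylphenyl group on the amide nitrogen.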